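The source may hold more compounds than are shown below. What is called first, only, known or untested is meant among the compounds shown, and "the series" means these compounds.

The three compounds share one core and differ only in the aryl group attached to it. Compound 1 `CCCCN(CC)c1cc(C)nc2c1NC(=O)CN2c1ccc(C)cc1Cl` gives "not determined" (no result reported) in an assay on HEK-293T cells for displacement of a labelled ligand from corticotropin-releasing factor receptor 2 (Homo sapiens), read by scintillation counting, with a stated time of 2 h, tested at 1 uM (a higher number here means more inhibition at the concentration tested (going by the name of the read-out), a lower number less inhibition), that is, no result was reported for it. Compound 3 `CCCCN(CC)c1cc(C)nc2c1NC(=O)CN2c1ccc(Cl)cc1Br` likewise gives "not determined" (no result reported) in this assay; for each of these two compounds the assay returned no number. Compound 2 `CCCCN(CC)c1cc(C)nc2c1NC(=O)CN2c1ccc(C(C)(C)C)cc1Br` gives -3.8% in this assay, which amounts to essentially no inhibition at the tested concentration. Compound 4 `CCCCN(CC)c1cc(C)nc2c1NC(=O)CN2c1ccc(C)cc1Br` is reached from compound 3 by methyl in place of chloro on an aromatic carbon. Going by the values given here, since compound 3 has no number, no step can be measured against it; the only anchor is compound 2, whose value of -3.8% indicates weak activity in this set, and a step beyond the scatter in either direction cannot be foreseen. Compound 4 is therefore expected to give 8% in this assay, within an estimated range of -15% to 40%.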

Compound 4, a percentage reported as inhibition, at one concentration (the size of the read-out at that concentration, not a potency): 5.5%
Estimate against measurement, compound 4: 2.5 percentage points above, within the range that was stated.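

With the bromo group kept, methyl in place of tert-butyl on the aromatic carbon meta to it gives a number 9.3 percentage points higher from compound 2 to compound 4 (within the scatter) in this assay, so these two groups are not told apart at this position. The step from chloro to methyl cannot be read, with no number for compound 3. No measurement shown bears on this result. Going by these compounds, what a carboxylic acid, an amine or a longer chain would give at this carbon remains open. So does whether any group there would raise inhibition clearly above that of compound 4, at 5.5%.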